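Amide nitrogen substituents on a shared diacyl thioether core

This account rests on a few compounds, and the source may have more. Where it says the series, first, only, none or still open, it means among the compounds named here.

In an assay on HEK293 cells for agonist activity at Toll-like receptor 2 (Homo sapiens) (on this read-out lower numbers stand for an effect already at smaller amounts and higher numbers for an effect only at larger amounts of compound), compound 3 `CCCCCCCCCCCC(=O)OC[C@H](CSC[C@@H](N)C(=O)NCCOCCOS(=O)(=O)O)OC(=O)CCCCCCCCCCC` gives 61 nM, the lowest number among the three measured compounds. Compound 1 `CCCCCCCCCCCC(=O)OC[C@H](CSC[C@@H](N)C(=O)N[C@@H](C)CO)OC(=O)CCCCCCCCCCC` gives 1560 nM and compound 2 `CCCCCCCCCCCC(=O)OC[C@H](CSC[C@@H](N)C(=O)NCCCC(C)(C)CO)OC(=O)CCCCCCCCCCC` gives 30700 nM. Compound 4 `CCCCCCCCCCCC(=O)OC[C@H](CSC[C@@H](N)C(=O)NC(C)c1ccc(O)cc1)OC(=O)CCCCCCCCCCC` removes the 2-(2-(sulfooxy)ethoxy)ethyl group of compound 3: 1-(4-hydroxyphenyl)ethyl in place of 2-(2-(sulfooxy)ethoxy)ethyl on an amide-type nitrogen. Among the compounds with values here, the steps that bear on this are a 26-fold lower number from compound 1 to compound 3 (1.41 log units; beyond the scatter) and a 500-fold lower number from compound 2 to compound 3 (2.70 log units; beyond the scatter), both large moves on gaining the sulfooxy group; a 20-fold higher number from compound 1 to compound 2 (1.29 log units; beyond the scatter) shows that another hydroxyl-bearing group without it gives a higher number still. Losing the sulfooxy group is therefore expected to raise the number, with a step of about a 49-fold higher number from compound 3 to compound 4 (1.69 log units; beyond the scatter). The estimate for compound 4 in this assay is 3000 nM, within a range of 500 nM to 20000 nM.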

Compound 4, half-maximal effective concentration: 2890 nM
Compound 4: middle estimate off by 1.0-fold (0.02 log units), on the high side, within the range that was stated.
By their numbers in this assay, from the lowest: compound 3; then compounds 1 and 4 (each within the scatter of the next); then compound 2.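

In this assay, an aromatic ring bearing a hydroxyl does not recover what 2-(2-(sulfooxy)ethoxy)ethyl gives on the amide-type nitrogen (a 47-fold higher number from compound 3 to compound 4 (1.68 log units; beyond the scatter)). 1-(4-hydroxyphenyl)ethyl cannot be told apart from 1-(hydroxymethyl)ethyl (a 1.9-fold higher number from compound 1 to compound 4 (0.27 log units; within the scatter)), yet it clearly differs from 4-(hydroxymethyl)-4-methylpentyl (an 11-fold lower number from compound 2 to compound 4 (1.03 log units; beyond the scatter)), so these hydroxyl-bearing groups do not all behave alike. Nothing available explains these steps.

Still open, going by these compounds, is whether the sulfooxy group alone carries the low number. A plain 2-(2-hydroxyethoxy)ethyl group or a carboxylic acid on the same chain would separate the end group from the chain.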